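A few compounds are considered here, and "the series" means these few. Any claim that something is new, unique, unknown or untested is made for them only; others in the source may bear on it.

In a functional assay on CHP-134 cells (Homo sapiens) for antiproliferative activity, with a stated time of 72 h (a higher number here means a weaker inhibitor, a lower number a stronger inhibitor), three compounds sharing one core have been measured. Compound 1 `Cc1ccc(NC(=O)CCN(Cc2ccc(C(=O)NO)cc2)C(=O)c2cc(C)cc(C)c2)cc1` gives 380 nM, compound 2 `O=C(CCN(Cc1ccc(C(=O)NO)cc1)C(=O)c1ccccc1)NCc1ccccc1` gives 4680 nM, and compound 3 `Cc1ccc(NC(=O)CCN(Cc2ccc(C(=O)NO)cc2)C(=O)c2ccccc2)cc1` gives 1160 nM, the middle number of the three.

Compound 4 `Cc1ccc(NC(=O)CCN(Cc2ccc(C(=O)NO)cc2)C(=O)c2ccc(N(C)C)cc2)cc1` differs from compound 3 by a single change: dimethylamino in place of hydrogen on an aromatic carbon, para to a large group (dimethylamino in place of hydrogen on an aromatic carbon). The measured step that bears most directly on this is a 3.1-fold higher number from compound 1 to compound 3 (0.48 log units; beyond the scatter), a modest change that puts phenyl in place of 3,5-dimethylphenyl on a carbonyl carbon. There, the compound with the added groups has the lower number. The other step, a 4.0-fold lower number from compound 2 to compound 3 (0.61 log units; beyond the scatter), puts 4-methylphenyl in place of benzyl on an amide-type nitrogen, so it concerns a different part of the molecule and offers little guidance here. For the measured compounds named here, no measured compound carries dimethylamino, so this expectation rests on one loose precedent.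

A modest step toward a lower number is expected, and it may not clear the scatter: a 1.8-fold lower number from compound 3 to compound 4 (0.25 log units; within the scatter). For compound 4, the estimated value is 650 nM, with an expected range of 220 nM to 1800 nM.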

Compound 4, half-maximal inhibitory concentration: 540 nM
Beside the measured number, compound 4's estimate is 1.2-fold (0.08 log units) above it, within the range that was stated.
By their numbers in this assay, from the lowest: compounds 1 and 4 (each within the scatter of the next); then compound 3; then compound 2.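

Until now, the only substituted ring on this carbonyl carbon was the 3,5-dimethylphenyl of compound 1. Compound 4 shows that a single dimethylamino, on an aromatic carbon para to a large group, also moves the result beyond the scatter in this assay, with a 2.1-fold lower number from compound 3 to compound 4 (0.33 log units; beyond the scatter). Against compound 1, a 1.4-fold higher number from compound 1 to compound 4 (0.15 log units; within the scatter) stays within the scatter, so 4-(dimethylamino)phenyl and 3,5-dimethylphenyl cannot be told apart here, and no data in hand say why the added group lowers the number.

Going by these compounds, whether a methyl, a methoxy or a morpholine at the same place would give a similar step remains open. So does whether dimethylamino would give the same step on compound 2, which carries benzyl in place of 4-methylphenyl on the amide-type nitrogen.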